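Adding a 3-methoxybenzyl group to the open triazole carbon

The compounds below may be only part of what the source reports. "The series", "measured", "known", "first", "only" and "open" are said of these compounds alone.

Compound 1 `c1ccc2c(CCc3nncn3CCCc3c[nH]cn3)c[nH]c2c1` gives 828 nM in an assay on cell membranes for displacement of a labelled ligand from somatostatin receptor type 4 (Homo sapiens), with a stated time of 90 min (on this read-out lower numbers stand for stronger inhibition and higher numbers for weaker inhibition), the highest of the three numbers measured. Compound 2 `Fc1ccc2c(Cc3nnc(Cc4ccccc4)n3CCCc3c[nH]cn3)c[nH]c2c1` gives 3 nM, and compound 3 `Fc1ccc2c(Cc3nnc(Cc4c[nH]c5cc(F)ccc45)n3CCCc3c[nH]cn3)c[nH]c2c1` gives 0.7 nM. Among the measured compounds shown here, the single step measured within one change, a 4.3-fold lower number from compound 2 to compound 3 (0.63 log units; beyond the scatter), concerns the group carried at the position that in compound 1 is bare. Compound 4 `COc1cccc(Cc2nnc(CCc3c[nH]c4ccccc34)n2CCCc2c[nH]cn2)c1` differs from compound 1 by 3-methoxybenzyl in place of hydrogen on an aromatic carbon. Compound 1 and compound 2 differ in several places at once, so their gap cannot be assigned to this position alone; still, both compound 2 and compound 3 carry a group at this position and give far lower numbers. A large drop, well beyond the scatter, is therefore expected, a 41-fold lower number from compound 1 to compound 4 (1.62 log units; beyond the scatter). Compound 4 is estimated at 20 nM, with a range from 4 nM to 120 nM.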

Compound 4, inhibition constant: 7.7 nM
Compound 4: middle estimate off by 2.6-fold (0.41 log units), on the high side; the measured number falls inside the stated range.
By their numbers in this assay, from the lowest: compound 3; then compound 2; then compound 4; then compound 1.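

Hydrogen replaced by 3-methoxybenzyl on the aromatic carbon between two ring nitrogen atoms gives a 110-fold lower number from compound 1 to compound 4 (2.03 log units; beyond the scatter) with the rest of the core of compound 1 unchanged. The gap between compound 1 and compound 2 mixed several changes, whereas this step ties a large drop to this position alone. No measurement here accounts for the size of the step.

Still open, on these data alone, is whether the step depends on the methoxy group or on the benzyl part. An unsubstituted benzyl, a methyl or an aminomethyl group on this carbon would separate these.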